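This account rests on a few compounds, and the source may have more. Where it says the series, first, only, none or still open, it means among the compounds named here.

Compound 1, `COc1cc(C(=O)c2cc(OC)c(OC)c(OC)c2)cc(NC(=O)/C=C/c2cc(OC)c(OC)c(OC)c2)c1OC`: 2500 nM in a functional assay on B16 cells (Mus musculus) for cytotoxicity, read by MTT assay, with a stated time of 72 h; on this read-out lower numbers stand for stronger inhibition and higher numbers for weaker inhibition
Compound 2, `COc1ccc(/C=C/C(=O)Nc2cc(C(=O)c3cc(OC)c(OC)c(OC)c3)cc(OC)c2OC)cc1N`: 12700 nM in this assay

Among the compounds with values here, compound 2 stands at the highest number of the two, so it is the weaker of the pair, with compound 1 as its only neighbour at a lower number. The step from compound 2 to compound 3, `C#CCOc1cccc(/C=C/C(=O)Nc2cc(C(=O)c3cc(OC)c(OC)c(OC)c3)cc(OC)c2OC)c1`, is 3-(propargyloxy)phenyl in place of 3-amino-4-methoxyphenyl on a double-bonded chain carbon bound to a double-bonded chain carbon. Within the data shown here, only one measured step bears on this place on the molecule: a 5.1-fold higher number from compound 1 to compound 2 (0.71 log units; beyond the scatter), which shows that changing the aromatic ring on the double-bonded chain carbon shifts the number well beyond the scatter. Nothing measured shows which way a 3-(propargyloxy)phenyl ring moves the number, so the direction is open; a shift of similar size in either direction is plausible. Compound 3 is therefore expected to land near compound 2, with wide uncertainty, at 10000 nM (range 3000 nM to 35000 nM), an expected step of a 1.3-fold lower number from compound 2 to compound 3 (0.10 log units; within the scatter).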

Compound 3, half-maximal inhibitory concentration: 5100 nM
Beside the measured number, compound 3's estimate is 2.0-fold (0.29 log units) above it; low and high end bracket the measured number.
By their numbers in this assay, from the lowest: compound 1; then compound 3; then compound 2.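

Replacing the ring on the double-bonded chain carbon can also lower the number in this assay: the 3-(propargyloxy)phenyl ring improves on 3-amino-4-methoxyphenyl (a 2.5-fold lower number from compound 2 to compound 3 (0.40 log units; beyond the scatter)). It does not match the 3,4,5-trimethoxyphenyl ring, however (a 2.0-fold higher number from compound 1 to compound 3 (0.31 log units; beyond the scatter)), so among these three rings, compound 1 keeps the lowest number, and both new steps lie beyond the scatter. Nothing available explains why the number shifts with these rings.

On these data alone, the swap to compound 3 removes the amine and the methoxy group and adds the propargyloxy group all at once, so the share of each change remains unknown. A 3-methoxyphenyl ring, which keeps the ether oxygen without the triple bond, and a 3-aminophenyl ring would be the simplest open comparisons.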